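Methoxy to nitro on the aromatic carbon

A few compounds are considered here, and "the series" means these few. Any claim that something is new, unique, unknown or untested is made for them only; others in the source may bear on it.

Values in a functional assay on HT-29 cells (Homo sapiens) for inhibition, read by sulforhodamine B assay, with a stated time of 48 h; a higher number here means a weaker inhibitor of growth, a lower number a stronger inhibitor of growth:
- compound 1 `CC(C)(C)NCc1c(C(=O)O)nn(-c2ccccc2)c1-c1ccc(Cl)cc1`: 353000 nM
- compound 2 `CC(C)(C)NCc1c(C(=O)O)nn(-c2ccccc2)c1-c1ccc(Br)cc1`: > 585000 nM (a limit)
- compound 3 `COc1ccc(-c2c(CNC(C)(C)C)c(C(=O)O)nn2-c2ccccc2)cc1`: > 659000 nM (a limit)

Compound 3 stands only at a limit, > 659000 nM, with no number behind it. Compound 4 `CC(C)(C)NCc1c(C(=O)O)nn(-c2ccccc2)c1-c1ccc([N+](=O)[O-])cc1` carries nitro in place of methoxy on an aromatic carbon, para to a large group: nitro in place of methoxy on an aromatic carbon. The nearest measured swaps are an at least 1.8-fold higher number from compound 1 to compound 3 (0.27 log units; that floor lies within the scatter) and an at least 1.6-fold higher number from compound 1 to compound 2 (0.21 log units; that floor lies within the scatter), and both floors lie within the scatter. The step that the two limits leave unreadable from compound 2 to compound 3 cannot be read. These steps support no expected change beyond the scatter in this assay, and no direction. The estimated step is an at least 1.1-fold lower number from compound 3 to compound 4 (0.07 log units; that floor lies within the scatter). Compound 4 is estimated at 550000 nM, with an expected range of 280000 nM to 800000 nM.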

Compound 4, concentration for 50% growth inhibition: > 634000 nM
Compound 4 gave a limit, no number; the forecaster's own chance of this, stated with the estimate: 65%; at least 1.1-fold (0.06 log units) between middle value and limit.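

In this assay, nitro at this place, para to a large group, also gives a limit and not a number: the limit of > 634000 nM in this assay, at which 1 of the 4 values shown sits. Within the data shown here, compound 1, with chloro, is now the only one of the four compounds with a number, and the one readable new step is an at least 1.7-fold higher number from compound 1 to compound 4 (0.25 log units; that floor lies within the scatter). The steps to compound 4 from compound 2 and from compound 3 cannot be read.

From the compounds shown here alone, the order among bromo, methoxy and nitro stays open. Also open, going by these compounds, is whether an amine or a carboxylic acid at this place would give a number clearly different from that of compound 1, 353000 nM.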